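The compounds below may be only part of what the source reports. "The series", "measured", "known", "first", "only" and "open" are said of these compounds alone.

In a functional assay for inhibition, with Homo sapiens as the target (a lower number here means a stronger inhibitor, a higher number a weaker inhibitor), compound 2 `COc1cccc(Nc2nccc(-c3ccco3)n2)c1` gives 400 nM. Compound 1 `c1cc(Nc2nccc(-c3ccco3)n2)cc(-n2ccnc2)c1` gives 800 nM, which is not separated from compound 2, while compound 3 `Cc1cccc(Nc2nccc(-c3ccco3)n2)c1` gives 2100 nM, clearly the higher number. Compound 4 `COc1cccc(Nc2nccc(-c3ccc(C)s3)n2)c1` carries 5-methylthiophen-2-yl in place of furan-2-yl (5-methylthiophen-2-yl in place of furan-2-yl on an aromatic carbon), on an aromatic carbon next to the ring nitrogen. The measured steps are a 2.0-fold lower number from compound 1 to compound 2 (0.30 log units; within the scatter), within the scatter, and the modest 2.6-fold higher number from compound 1 to compound 3 (0.42 log units; beyond the scatter) and a 5.3-fold higher number from compound 2 to compound 3 (0.72 log units; beyond the scatter). All three replace a group elsewhere in the molecule, so none tests this place and none gives a direction. Expected in this assay is a 1.5-fold higher number from compound 2 to compound 4 (0.18 log units; within the scatter), so no step beyond the scatter is anticipated. For compound 4 the estimate is 600 nM, with an expected range of 150 nM to 2500 nM.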

Compound 4, half-maximal inhibitory concentration: 2300 nM
For compound 4 the middle estimate is 3.8-fold (0.58 log units) below the measured one, within the range that was stated.
By their numbers in this assay, from the lowest: compounds 2 and 1 (each within the scatter of the next); then compounds 3 and 4 (each within the scatter of the next).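

In this assay this position gives its first readable step, a 5.8-fold higher number from compound 2 to compound 4 (0.76 log units; beyond the scatter), so 5-methylthiophen-2-yl in place of furan-2-yl on the aromatic carbon next to the ring nitrogen does not leave the number unchanged. The earlier steps shown here all lay elsewhere in the molecule and gave no direction here. Nothing available explains this rise.

The change swaps sulfur for oxygen and adds a methyl at once, so the two remain unseparated. From the compounds shown here alone, whether unsubstituted thiophen-2-yl, 5-methylfuran-2-yl or an amine at this place would stand nearer compound 2 or compound 4 stays open.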